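Hydroxy to Methoxy on Two Related Amides

The compounds below may be only part of what the source reports. "The series", "measured", "known", "first", "only" and "open" are said of these compounds alone.

Compound 1 `COc1cc(Cl)c(-c2nc(SCC(=O)NC3CC3)nc3[nH]cc(C#N)c23)cc1OC`: in a functional assay on HCT-116 cells (Homo sapiens) for antiproliferative activity, read by sulforhodamine B assay, with a stated time of 4 days (a higher number here means a weaker inhibitor of growth, a lower number a stronger inhibitor of growth), compound 1 gives 60 nM.
Compound 2 `COc1cc(Cl)c(-c2nc(SCC(=O)NC3CC3)nc3[nH]cc(C#N)c23)cc1O`: in this assay compound 2 gives 1160 nM.
Compound 3 `COc1cc(Cl)c(-c2nc(SCC(=O)N3CCC3)nc3[nH]cc(C#N)c23)cc1O`: in this assay compound 3 gives 172 nM.

These three compounds share one core and differ at two places. Compound 2 carries a free hydroxy on its aromatic ring and a cyclopropylamino on its amide carbonyl. Compound 1 differs from compound 2 by methyl in place of hydrogen on an oxygen on an aromatic ring, and that change brought a 19-fold lower number from compound 2 to compound 1 (1.29 log units; beyond the scatter). Compound 3 differs from compound 2 by azetidin-1-yl in place of cyclopropylamino on a carbonyl carbon, which brought a 6.7-fold lower number from compound 2 to compound 3 (0.83 log units; beyond the scatter). For the measured compounds named here, compound 1 and compound 3 differ at both places at once, so no single step links them; their values simply show compound 1 with the lower number.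

Compound 4 `COc1cc(Cl)c(-c2nc(SCC(=O)N3CCC3)nc3[nH]cc(C#N)c23)cc1OC` has not yet been measured. It differs from compound 3 by methyl in place of hydrogen on an oxygen on an aromatic ring. The place is identical, word for word, to the place of the change between compound 2 and compound 1, so this is the same change, seen for a second time in this set.

Compound 4 is therefore expected to give a step of an 11-fold lower number from compound 3 to compound 4 (1.06 log units; beyond the scatter). Going by the values given here, this rests on the single earlier instance of the change, a 19-fold lower number from compound 2 to compound 1 (1.29 log units; beyond the scatter), tempered by the fact that only one example exists and that compound 1 itself stands at 60 nM. Compound 4 is estimated at 15 nM, within a range from 5 nM to 60 nM.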

Compound 4, concentration for 50% growth inhibition: 28 nM
Estimate against measurement, compound 4: 1.9-fold (0.27 log units) below; the range from low to high includes it.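

Hydroxy to methoxy again lowered the number in this assay when carried over to the azetidin-1-yl amide, giving a 6.1-fold lower number from compound 3 to compound 4 (0.79 log units; beyond the scatter), so the direction of the change held on the second core while its size did not: the same change on two cores in this assay, a 19-fold lower number (1.29 log units; beyond the scatter) from compound 2 to compound 1 and a 6.1-fold lower number (0.79 log units; beyond the scatter) from compound 3 to compound 4, 3.1-fold (0.50 log units) apart, beyond the scatter of two such steps

Azetidin-1-yl in place of cyclopropylamino, read this time on the two methoxy compounds, gave a 2.1-fold lower number from compound 1 to compound 4 (0.33 log units; beyond the scatter), which is again the same direction with a different size: the same change on two cores in this assay, a 6.7-fold lower number (0.83 log units; beyond the scatter) from compound 2 to compound 3 and a 2.1-fold lower number (0.33 log units; beyond the scatter) from compound 1 to compound 4, 3.1-fold (0.50 log units) apart, beyond the scatter of two such steps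

These two gaps come from the same four compounds, so they are one observation seen from two sides: each change did less where the other was already present, and a step measured on one core here gave the direction but not the size of the step on the other, while nothing in these numbers shows why this happens or whether it would hold for any further pair.

The compounds shown leave open whether a longer chain on the oxygen, such as ethoxy, or an amine in place of the hydroxy would follow the methoxy result. They also leave open whether a larger ring on the carbonyl carbon, such as pyrrolidin-1-yl, would extend the azetidin-1-yl result or behave differently on the hydroxy and methoxy compounds.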